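The source may report more compounds than this note shows. Statements on the series, on what has been measured and on what is new or still open speak of the compounds shown alone.

Measured so far in an in vivo ADME assay on the whole organism (strain Sprague-Dawley) for pharmacokinetics, with Rattus norvegicus as the target, at a dose of 2 mg/kg by the intravenous route; on this read-out higher numbers stand for wider distribution into tissues and lower numbers for narrower distribution
compound 1 `N#Cc1cc(Cl)cc(Oc2cc(OCc3noc4nc(N)ccc34)ccc2Cl)c1` gives 44.7 L/kg
compound 2 `N#Cc1cc(Cl)cc(Oc2cc(OCc3n[nH]c4nc(N)ccc34)cc(F)c2Cl)c1` gives 3.5 L/kg

Of these two numbers, compound 2 has the lower, and its gap to compound 1 lies beyond the scatter. Compound 3 `N#Cc1cc(Cl)cc(Oc2cc(OCc3noc4nc(N)ccc34)cc(F)c2Cl)c1` differs from compound 2 in one place: a group of 10 heavy atoms (6 carbon, 3 nitrogen, 1 oxygen; one five-membered aromatic ring with 2 hetero atoms, one six-membered aromatic ring with 1 hetero atom) in place of a group of 10 heavy atoms (6 carbon, 4 nitrogen; one five-membered aromatic ring with 2 hetero atoms, one six-membered aromatic ring with 1 hetero atom), on a saturated chain carbon bound to an oxygen on an aromatic ring. The entering group also stands in compound 1, which gives 44.7 L/kg, but compound 1 differs from compound 3 in another place, so only part of that gap is expected to carry over. In this assay the expected change is a 4.3-fold higher number from compound 2 to compound 3 (0.63 log units; beyond the scatter), upward and beyond the scatter. For compound 3 the estimate is 15 L/kg, with an expected range from 5 L/kg to 45 L/kg.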

Compound 3, volume of distribution: 5.1 L/kg
Compound 3: the middle estimate sits 2.9-fold (0.47 log units) above what was measured; low and high end bracket the measured number.
By their numbers in this assay, from the lowest: compounds 2 and 3 (each within the scatter of the next); then compound 1.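

In this assay the exchange of groups on a saturated chain carbon bound to an oxygen on an aromatic ring gives a 1.5-fold higher number from compound 2 to compound 3 (0.16 log units; within the scatter) and so does not separate the two groups at this position. Fluoro in place of hydrogen on an aromatic carbon gives an 8.8-fold lower number from compound 1 to compound 3 (0.94 log units; beyond the scatter) and is the larger of the two steps. Nothing shown gives a reason for either step.

From the compounds shown here alone, whether methoxy or an amine on that aromatic carbon would give a step like that of fluoro stays open. So does whether the group exchange reads the same on a core carrying hydrogen instead of fluoro.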